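This account rests on a few compounds, and the source may have more. Where it says the series, first, only, none or still open, it means among the compounds named here.

In a functional assay on A2780 cells (Homo sapiens) for antiproliferative activity, read by resazurin assay, with a stated time of 72 h (a lower number here means a stronger inhibitor, a higher number a weaker inhibitor), three compounds with a shared core have numbers: compound 1 `CN(Cc1ccccc1F)C(=O)c1cc2c(Cc3ccccc3)n[nH]c2cc1O` gives 1500 nM, compound 2 `CN(Cc1cccc(Cl)c1)C(=O)c1cc2c(Cc3ccccc3)n[nH]c2cc1O` gives 5300 nM, and compound 3 `CN(Cc1cccc(Br)c1)C(=O)c1cc2c(Cc3ccccc3)n[nH]c2cc1O` gives 7100 nM. Compound 3 sits at the high end of these numbers, level with compound 2: a 1.3-fold higher number from compound 2 to compound 3 (0.13 log units; within the scatter). Changing the aryl group gave larger steps: a 3.5-fold higher number from compound 1 to compound 2 (0.55 log units; beyond the scatter), and a 4.7-fold higher number from compound 1 to compound 3 (0.68 log units; beyond the scatter). Compound 4 `CCOc1ccc(CN(C)C(=O)c2cc3c(Cc4ccccc4)n[nH]c3cc2O)cc1` has 4-ethoxyphenyl in place of 3-bromophenyl on a saturated chain carbon bound to an amide-type nitrogen. For the measured compounds named here, no measured compound carries 4-ethoxyphenyl, so the direction in this assay is uncertain, and no step beyond the scatter is expected. The expected step is a 1.4-fold lower number from compound 3 to compound 4 (0.15 log units; within the scatter). Compound 4 is estimated at 5000 nM, with an expected range of 1800 nM to 14000 nM.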

Compound 4, half-maximal inhibitory concentration: 3200 nM
Compound 4: the middle estimate sits 1.6-fold (0.19 log units) above what was measured, within the range that was stated.
By their numbers in this assay, from the lowest: compound 1; then compounds 4, 2 and 3 (each within the scatter of the next, the first and the last beyond it).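

In this assay, 4-ethoxyphenyl, which unlike 3-bromophenyl counts a hydrogen-bond acceptor, shows that this position can take a quite different aryl group with a better result than 3-bromophenyl (a 2.2-fold lower number from compound 3 to compound 4 (0.35 log units; beyond the scatter)), while it stays level with 3-chlorophenyl (a 1.7-fold lower number from compound 2 to compound 4 (0.22 log units; within the scatter)). The 2-fluorophenyl of compound 1 still keeps the lowest number (a 2.1-fold higher number from compound 1 to compound 4 (0.33 log units; beyond the scatter)). No measurement here explains these steps.

The compounds shown leave open whether the ethoxy group itself or its place on the ring sets this number. On these data alone, how a methoxy group, a longer propoxy chain or an amine in its place would read also remains open.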